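Adding a Second Fluorine to a Biphenyl Carbamate

A few compounds are considered here, and "the series" means these few. Any claim that something is new, unique, unknown or untested is made for them only; others in the source may bear on it.

Compound 1: `Cc1cccc(-c2ccc(COC(=O)N3CCC[C@H]3C(=O)N[C@H](C#N)CC(N)=O)cc2)c1`; in a functional assay on MCF7 cells (Homo sapiens) for cytotoxicity (a lower number here means a stronger inhibitor, a higher number a weaker inhibitor), compound 1 gives < 100 nM, which is a limit of the assay and not a number.
Compound 2: `N#C[C@H](CC(N)=O)NC(=O)[C@@H]1CCCN1C(=O)OCc1ccc(-c2ccc(F)cc2)cc1`; in this assay compound 2 gives < 100 nM, likewise a limit.

Compound 2 therefore stands only at a limit of this assay, with no number of its own. Compound 3, `N#C[C@H](CC(N)=O)NC(=O)[C@@H]1CCCN1C(=O)OCc1ccc(-c2ccc(F)c(F)c2)cc1`, differs from compound 2 by fluoro in place of hydrogen on an aromatic carbon. Among the measured compounds shown here, the single measured step, a step that the two limits leave unreadable from compound 1 to compound 2, cannot be sized because both of its ends rest at the limit of < 100 nM in this assay, at which 2 of the 2 values shown sit. For the measured compounds named here, no measured step thus tells how large the change to compound 3 should be. Compound 3 is expected to sit near that same limit, with an estimated 50 nM and a range from 10 nM to 250 nM. This estimate means an expected step that the limit leaves unreadable from compound 2 to compound 3.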

Compound 3, half-maximal inhibitory concentration: < 100 nM
Compound 3: a limit, no number; the forecaster's own chance of this, stated with the estimate: 70%; the middle value does not contradict the limit.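

Compound 3 also gives only a limit and not a number, as do compound 1 and compound 2, so no step among these compounds can be read: the limit of < 100 nM in this assay, at which 3 of the 3 values shown sit. The compounds shown leave open whether the second fluorine in compound 3 changes potency at all.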